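Hydroxy to methoxy on compound 2: expected cytotoxicity

This account rests on a few compounds, and the source may have more. Where it says the series, first, only, none or still open, it means among the compounds named here.

Measured so far in an ADME assay on THP-1 cells (Homo sapiens) for cytotoxicity, read by flow cytometry and propidium iodide staining, with a stated time of 72 h; on this read-out higher numbers stand for weaker inhibition and lower numbers for stronger inhibition
compound 1 `Nc1ccc2oc(-c3ccccc3)c(O)c(=O)c2c1` gives 27000 nM
compound 2 `COc1ccccc1-c1oc2ccc(N)cc2c(=O)c1O` gives 102000 nM
compound 3 `Nc1ccc2oc(-c3ccccc3F)c(O)c(=O)c2c1` gives 38000 nM

Compound 2 carries the highest of these numbers. Two steps are modest and beyond the scatter: a 3.8-fold higher number from compound 1 to compound 2 (0.58 log units; beyond the scatter) for methoxy in place of hydrogen on an aromatic carbon and a 2.7-fold lower number from compound 2 to compound 3 (0.43 log units; beyond the scatter) for fluoro in place of methoxy on an aromatic carbon. A third, a 1.4-fold higher number from compound 1 to compound 3 (0.15 log units; within the scatter) for fluoro in place of hydrogen on an aromatic carbon, stays within the scatter.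

Compound 4 `COc1ccccc1-c1oc2ccc(N)cc2c(=O)c1OC` differs from compound 2 by methyl in place of hydrogen on an oxygen on an aromatic ring (methyl in place of hydrogen on an oxygen on an aromatic ring, or hydroxy to methoxy). Among the compounds with values here, none of the measured steps touches that hydroxy, so they offer no direct precedent and no direction. They serve only as a guide to size, and the largest of them is a 3.8-fold higher number from compound 1 to compound 2 (0.58 log units; beyond the scatter) and remains modest. In this assay no step beyond the scatter is therefore expected, although a modest one in either direction remains possible. The expected step is a 1.3-fold lower number from compound 2 to compound 4 (0.11 log units; within the scatter) as a central estimate. For compound 4 the estimated value is 80000 nM with an expected range from 30000 nM to 200000 nM in this assay.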

Compound 4, half-maximal inhibitory concentration: 116000 nM
Compound 4: middle estimate off by 1.5-fold (0.16 log units), on the low side; low and high end bracket the measured number.
By their numbers in this assay, from the lowest: compounds 1 and 3 (each within the scatter of the next); then compounds 2 and 4 (each within the scatter of the next).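

In this assay, within the data shown here, the change from hydroxy to methoxy gives a 1.1-fold higher number from compound 2 to compound 4 (0.06 log units; within the scatter) and so provides the first reading at this oxygen, since the earlier steps all concerned an aromatic carbon. On the background of compound 2, methyl can therefore take the place of hydrogen on this oxygen with no change that can be read on this scale, whereas methoxy in place of hydrogen on the aromatic carbon gave a 3.8-fold higher number from compound 1 to compound 2 (0.58 log units; beyond the scatter) and moved the number beyond the scatter. The compounds shown offer no independent data that could explain the flat result at this oxygen.

This single pair does not show whether the same holds on the background of compound 1 or compound 3, where the aromatic carbon carries hydrogen or fluoro instead of methoxy. It also leaves open how this oxygen tolerates anything other than methyl, such as an ethyl group, a longer chain or a chain ending in an amine or a carboxylic acid.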